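The compounds below may be only part of what the source reports. "The series", "measured", "known", "first", "only" and "open" are said of these compounds alone.

Measured so far in a functional assay on NCI-H460 cells (Homo sapiens) for inhibition, read by CCK-8 assay, with a stated time of 72 h; on this read-out lower numbers stand for stronger inhibition and higher numbers for weaker inhibition:

compound 1, `Nc1ccccc1NC(=O)c1ccc(CNC(=O)c2n[nH]cc2NC(=O)c2c(F)cccc2Cl)cc1`, gives 3630 nM
compound 2, `Nc1ccccc1NC(=O)c1ccc(CNC(=O)c2n[nH]cc2NC(=O)c2c(Cl)cccc2Cl)cc1`, gives 4190 nM
compound 3, `O=C(NO)c1ccc(CNC(=O)c2n[nH]cc2NC(=O)c2ccccc2F)cc1`, gives 23700 nM

Compounds 1 and 2 share one core; the move between them is chloro in place of fluoro on an aromatic carbon and the step reads a 1.2-fold higher number from compound 1 to compound 2 (0.06 log units; within the scatter). Compound 3 carries a different core; how it differs from compound 1 is not broken down here, and its half-maximal inhibitory concentration is the highest of the three.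

Compound 4, `O=C(NO)c1ccc(CNC(=O)c2n[nH]cc2NC(=O)c2ccccc2Cl)cc1`, is not yet measured. It differs from compound 3 by chloro in place of fluoro on an aromatic carbon. This is the same kind of change as that from compound 1 to compound 2, with one difference around the place: in compound 1 the site is also meta to a chloro group, which compound 3 lacks.

The step is expected to be small, a 1.1-fold higher number from compound 3 to compound 4 (0.06 log units; within the scatter), because a 1.2-fold higher number from compound 1 to compound 2 (0.06 log units; within the scatter) was within the scatter. Compound 4 is therefore estimated at 27000 nM, between 12000 nM and 60000 nM.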

Compound 4, half-maximal inhibitory concentration: 6170 nM
The estimate for compound 4 lay 4.4-fold (0.64 log units) above the measured number; measured number below the stated range.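

Chloro in place of fluoro gives a 3.8-fold lower number from compound 3 to compound 4 (0.58 log units; beyond the scatter) in this assay. The size of this step does not carry over between the core of compound 1 and the core of compound 3: the same change on two cores in this assay, a 1.2-fold higher number (0.06 log units; within the scatter) from compound 1 to compound 2 and a 3.8-fold lower number (0.58 log units; beyond the scatter) from compound 3 to compound 4, 4.4-fold (0.65 log units) apart, beyond the scatter of two such steps

With a single pair on each core, and with a further chloro group on the ring in compound 1 that compound 3 lacks, the data do not show whether the core or that chloro group accounts for the gap. Still open, on these data alone, is whether a second halogen on the ring of compound 3 would shrink the step, and whether bromo, methyl or methoxy at the same place would follow the pattern of either core.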